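Sulfonamide nitrogen substituent: isopropyl to hydroxymethyl

The source may report more compounds than this note shows. Statements on the series, on what has been measured and on what is new or still open speak of the compounds shown alone.

Among the measured compounds shown here, compound 2 `CCC1C(=O)N(C)c2cnc(Nc3ccc(S(=O)(=O)NCC(C)C)cc3)nc2N1c1ccn(C)n1` has the higher of the two numbers so far in an assay for inhibition of serine/threonine-protein kinase PLK2 (Homo sapiens), read by FRET and Z'-LYTE, with a stated time of 1 h; a higher number here means a weaker inhibitor, a lower number a stronger inhibitor: compound 2 gives 311 nM, while compound 1 `CCC1C(=O)N(C)c2cnc(Nc3ccc(S(=O)(=O)NC)cc3)nc2N1c1ccn(C)n1` gives 71.6 nM. For the measured compounds named here, the only step in hand, a 4.3-fold higher number from compound 1 to compound 2 (0.64 log units; beyond the scatter), adds an isopropyl at the sulfonamide nitrogen chain carbon. Compound 3 `CCC1C(=O)N(C)c2cnc(Nc3ccc(S(=O)(=O)NCCO)cc3)nc2N1c1ccn(C)n1` changes this place again: hydroxymethyl in place of isopropyl on a saturated chain carbon bound to a sulfonamide nitrogen. With the isopropyl removed, the number is expected to move back down, by about a 2.8-fold lower number from compound 2 to compound 3 (0.45 log units; beyond the scatter). Compound 3 is therefore estimated at 110 nM in this assay, within 50 nM to 250 nM.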

Compound 3, half-maximal inhibitory concentration: 478 nM
Compound 3: middle estimate off by 4.3-fold (0.64 log units), on the low side, and the stated range ends below it.
By their numbers in this assay, from the lowest: compound 1; then compounds 2 and 3 (each within the scatter of the next).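

In this assay the move from isopropyl to hydroxymethyl gives a 1.5-fold higher number from compound 2 to compound 3 (0.19 log units; within the scatter) and so leaves the two groups unresolved, even though hydroxymethyl brings a hydrogen-bond donor and acceptor that isopropyl lacks. The same hydroxymethyl group, read against compound 1, gives a 6.7-fold higher number from compound 1 to compound 3 (0.82 log units; beyond the scatter) and shows that the higher number holds for both compound 2 and compound 3 at this place. No measurement offered here accounts for this result.

On these data alone, whether an amine, a carboxylic acid or a longer chain at this saturated chain carbon would read with compound 2 and compound 3 or with compound 1 remains open.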